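The source may report more compounds than this note shows. Statements on the series, on what has been measured and on what is new or still open speak of the compounds shown alone.

In an assay on HEK293 cells for inhibition of Voltage-dependent N-type calcium channel subunit alpha-1B (Homo sapiens), read by FLIPR and calcium flux, in the presence of a further agent that is not named here (on this read-out higher numbers stand for weaker inhibition and lower numbers for stronger inhibition), compound 2 `O=C(c1cccc(OC(F)(F)F)c1)N1CCC(N(C2CC2)S(=O)(=O)c2cccc(C(F)(F)F)c2)CC1` gives 370 nM. Among the three numbers in hand this is the second highest: compound 1 `COC(=O)c1cccc(C(=O)N2CCC(N(C3CC3)S(=O)(=O)c3cccc(C(F)(F)F)c3)CC2)c1` gives 380 nM, and compound 3 `O=C(c1ccc(OC(F)(F)F)cc1)N1CCC(N(C2CC2)S(=O)(=O)c2cccc(C(F)(F)F)c2)CC1` gives 300 nM. Compound 4 `CN(C)c1cccc(C(=O)N2CCC(N(C3CC3)S(=O)(=O)c3cccc(C(F)(F)F)c3)CC2)c1` differs from compound 2 by dimethylamino in place of trifluoromethoxy on an aromatic carbon. Going by the values given here, two measured steps bear on this position. Exchanging the group on that aromatic carbon once before gave a 1.0-fold lower number from compound 1 to compound 2 (0.01 log units; within the scatter), and replacing the 3-(trifluoromethoxy)phenyl with 4-(trifluoromethoxy)phenyl gave a 1.2-fold lower number from compound 2 to compound 3 (0.09 log units; within the scatter). Both changes stayed within the scatter, so the exchange in compound 4 is expected to alter this assay little, with no step beyond the scatter in either direction. Compound 4 is therefore estimated at 400 nM, with a range from 150 nM to 1100 nM. That estimate is expected to amount to a 1.1-fold higher number from compound 2 to compound 4 (0.03 log units; within the scatter).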

Compound 4, half-maximal inhibitory concentration: 240 nM
Estimate against measurement, compound 4: 1.7-fold (0.22 log units) above; the range from low to high includes it.
By their numbers in this assay, from the lowest: compounds 4, 3, 2 and 1 (each within the scatter of the next).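

Dimethylamino, with fewer heavy atoms and no fluorine, also fits on this aromatic carbon in this assay (a 1.5-fold lower number from compound 2 to compound 4 (0.19 log units; within the scatter)) and stays within the scatter of the methoxycarbonyl compound (a 1.6-fold lower number from compound 1 to compound 4 (0.20 log units; within the scatter)) and of the 4-(trifluoromethoxy)phenyl compound (a 1.3-fold lower number from compound 3 to compound 4 (0.10 log units; within the scatter)). Three different groups at this place therefore leave compounds 1, 2 and 4 within the scatter of one another. No available evidence explains this flat result. From the compounds shown here alone, whether a primary amine, a carboxylic acid or a longer chain here would produce a step beyond the scatter remains open.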